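A few compounds are considered here, and "the series" means these few. Any claim that something is new, unique, unknown or untested is made for them only; others in the source may bear on it.

Measured in an ADME assay on Vero cells (Chlorocebus sabaeus) for cytotoxicity, read by sulforhodamine B assay, with a stated time of 72 h; on this read-out lower numbers stand for stronger inhibition and higher numbers for weaker inhibition:
Compound 1, `CN1Cc2ccc(OCc3ccc(-c4ccccc4)cc3)cc2[C@@H](O)C1`, gives 23000 nM.
Compound 2, `CN1Cc2ccc(OCc3ccc(-c4ccc(-c5ccccc5)cc4)cc3)cc2[C@@H](O)C1`, gives 280 nM.
Compound 3, `CN1CCc2cc(-c3ccccc3)ccc2C1`, gives only a limit of the assay, > 50000 nM.

Compound 2 differs from compound 1 in one place: phenyl in place of hydrogen on an aromatic carbon. That single change produced an 82-fold lower number from compound 1 to compound 2 (1.91 log units; beyond the scatter). The core of compound 3 is a different one, and how it differs from the core of compound 1 is not broken down here. Compound 4, `CN1CCc2cc(-c3ccc(-c4ccccc4)cc3)ccc2C1`, has not yet been measured in this assay; it stands to compound 3 as compound 2 stands to compound 1, carrying the same change: phenyl in place of hydrogen on an aromatic carbon. Because compound 3 sits at the limit of > 50000 nM in this assay, at which 1 of the 3 values shown sits, the starting point of this second step is known only as a limit, so its size can be judged from the one worked example alone. The expected step is an at least 16-fold lower number from compound 3 to compound 4 (1.22 log units; beyond the scatter), set beside the earlier one, an 82-fold lower number from compound 1 to compound 2 (1.91 log units; beyond the scatter), and resting on nothing more. The expected value for compound 4 in this assay is therefore 3000 nM, estimated to lie between 600 nM and 20000 nM.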

Compound 4, half-maximal inhibitory concentration: 15600 nM
Compound 4: the middle estimate sits 5.2-fold (0.72 log units) below what was measured; low and high end bracket the measured number.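

In this assay phenyl in place of hydrogen on an aromatic carbon lowered the number on the second core as well, giving an at least 3.2-fold lower number from compound 3 to compound 4 (0.50 log units; beyond the scatter). Compound 3 gives > 50000 nM, which is a limit of the assay and not a number. The direction of the change therefore held on both cores shown, but this is only one pair of cores, and the size of the step on the second core remains unsettled, so it cannot be said whether the change carries over with the same strength: the same change on two cores in this assay, an 82-fold lower number (1.91 log units; beyond the scatter) from compound 1 to compound 2 and an at least 3.2-fold lower number (0.50 log units; beyond the scatter) from compound 3 to compound 4; the limit leaves it open whether they differ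

The compounds shown leave open whether a different group in the same place, such as a pyridine ring, a methyl group or a carboxylic acid on the added phenyl, would lower the number as phenyl does. They also leave open how the core of compound 1 and the core of compound 3 compare with each other, since those two compounds differ in more than one place.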